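A few compounds are considered here, and "the series" means these few. Any claim that something is new, unique, unknown or untested is made for them only; others in the source may bear on it.

In an ADME assay on L6 cells (Rattus norvegicus) for cytotoxicity, with a stated time of 72 h (a lower number here means a stronger inhibitor, a higher number a weaker inhibitor), compound 1 (`CC(C)(C)C(=O)OC1CC2(N3CCCCC3)CC(c3ccccc3)C1C(c1ccccc1)C2`) gives 12000 nM and compound 2 (`CCN(CC)CC(=O)OC1CC2(N3CCCC3)CC(c3ccccc3)C1C(c1ccccc1)C2`) gives 49000 nM while compound 3 (`O=C(CN1CCCCC1)OC1CC2(N3CCCC3)CC(c3ccccc3)C1C(c1ccccc1)C2`) gives 14200 nM on the same read-out. Compound 3 therefore sits within the scatter of compound 1 and well short of the number for compound 2.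

Compound 4 (`O=C(CN1CCCCC1)OC1CC2(N3CCCCC3)CC(c3ccccc3)C1C(c1ccccc1)C2`) differs from compound 3 in one place only: piperidin-1-yl in place of pyrrolidin-1-yl on a saturated ring carbon with piperidin-1-yl in place of pyrrolidin-1-yl on a saturated ring carbon. Within the data shown here, no measured pair makes this exchange directly.

Among the measured compounds shown here, the one measured step is a 3.5-fold lower number from compound 2 to compound 3 (0.54 log units; beyond the scatter) and it is modest, but it brought in piperidin-1-yl in place of diethylamino on a saturated chain carbon bound to a carbonyl carbon, not on the ring carbon, so it bears on the question only indirectly. Compound 1 offers a closer hint: it already carries piperidin-1-yl on that ring carbon, and with its different ester group it gives 12000 nM within the scatter of compound 3.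

No step beyond the scatter is therefore expected, with only a slight lean towards a lower number. The expected step is a 1.3-fold lower number from compound 3 to compound 4 (0.11 log units; within the scatter) as a rough estimate. Compound 4 is estimated at 11000 nM with an expected span from 5000 nM to 22000 nM for the measurement still to come.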

Compound 4, half-maximal inhibitory concentration: 60400 nM
Compound 4: the middle estimate sits 5.5-fold (0.74 log units) below what was measured, and the stated range ends below it.
By their numbers in this assay, from the lowest: compounds 1 and 3 (each within the scatter of the next); then compounds 2 and 4 (each within the scatter of the next).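

In this assay, the ring carbon bearing the amine proves sensitive to which amine it carries: with the (((piperidin-1-yl)methyl)carbonyl)oxy group held constant, piperidin-1-yl in place of pyrrolidin-1-yl gives a 4.3-fold higher number from compound 3 to compound 4 (0.63 log units; beyond the scatter) and so moves the number beyond the scatter. The group on the carbonyl carbon also counts when piperidin-1-yl sits on that ring carbon, since (piperidin-1-yl)methyl in place of tert-butyl gives a 5.0-fold higher number from compound 1 to compound 4 (0.70 log units; beyond the scatter) and this step too lies beyond the scatter. Nothing measured here accounts for either step.

The compounds shown do not tell whether the pyrrolidin-1-yl to piperidin-1-yl exchange on the ring carbon would move the number the same way with diethylamino or tert-butyl in place of the piperidin-1-yl group on the ester side. They also leave open how other amines on that ring carbon, such as morpholin-4-yl, dimethylamino or azepan-1-yl, would read in this assay on the same core.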